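A few compounds are considered here, and "the series" means these few. Any claim that something is new, unique, unknown or untested is made for them only; others in the source may bear on it.

Working notes on the series. In a functional assay on K562 cells (Homo sapiens) for cytotoxicity, read by MTT assay, with a stated time of 5 days (a higher number here means a weaker inhibitor, a lower number a stronger inhibitor), compound 1 `COc1ccc(-c2cnnn2Cc2cc(OC)c(OC)c(OC)c2)cc1O` gives 530 nM, so a measurable value is available in this series. Compound 2 `COc1ccc(-c2cn(-c3cc(OC)c(OC)c(OC)c3)nn2)cc1` gives > 10000 nM in this assay, which is a limit of the assay and not a number. Its true position is therefore unknown, and it offers no exact starting point.

Compound 3 `COc1ccc(-c2cn(-c3cc(OC)c(OC)c(OC)c3)nn2)cc1N` keeps the structure of compound 2 but has amino in place of hydrogen on an aromatic carbon, ortho to a methoxy group and meta to a large group: amino in place of hydrogen on an aromatic carbon.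

For the measured compounds named here, no measured single-place step is available to calibrate this change. Compound 1, at 530 nM, differs from compound 2 in more than one place, so it gives only weak support for expecting a measurable value. A shift toward stronger inhibition in this assay is expected, of moderate size, with a real chance that the reading stays at the limit. The expected change is an at least 3.3-fold lower number from compound 2 to compound 3 (0.52 log units; beyond the scatter). Compound 3 is estimated at 3000 nM, with an expected range of 500 nM to 15000 nM.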

Compound 3, half-maximal inhibitory concentration: 1300 nM
Estimate against measurement, compound 3: 2.3-fold (0.36 log units) above; low and high end bracket the measured number.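

Amino in place of hydrogen on an aromatic carbon, ortho to a methoxy group and meta to a large group, brings the series off the limit in this assay, with an at least 7.6-fold lower number from compound 2 to compound 3 (0.88 log units; beyond the scatter). For the compounds shown here, this is the first single-place step, and it shows that a measurable value can be reached from compound 2 by a change at this one position alone, without the other differences that separate compound 1 from compound 2. Compound 2 has only a limit, > 10000 nM, which is a limit of the assay and not a number, so the printed step gives a minimum and its true size stays unknown: the limit of > 10000 nM in this assay, at which 1 of the 3 values shown sits.

The compounds shown do not tell whether the step belongs to amino itself or would follow from other groups at this carbon; a dimethylamino group, an acetamido group or a fluorine atom in the same place would separate these cases. Nor do they tell how the amino change behaves on the core of compound 1, which differs from compound 3 in more than one place and so gives no step.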